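This account rests on a few compounds, and the source may have more. Where it says the series, first, only, none or still open, it means among the compounds named here.

In a functional assay on CHO cells for agonist activity at Free fatty acid receptor 1 (Homo sapiens), read by a luciferase reporter (on this read-out higher numbers stand for larger maximal responses and lower numbers for smaller maximal responses), compound 1 `Cc1nc(-c2ccc(C(F)(F)F)cc2)sc1CNc1ccc(CCC(=O)O)cc1` gives 108% and stands highest of the two numbers measured here. Compound 2 `O=C(O)CSc1ccc(NCc2cccc(Oc3ccccc3)c2)cc1` in this assay gives 84%, a gap that lies beyond the usual scatter. Compound 3 `Cc1nc(-c2ccc(C(F)(F)F)cc2)sc1CNc1ccc(CCC(=O)NC(C)C)cc1` has not been measured; it differs from compound 1 only in that (isopropylamino in place of hydroxy on a carbonyl carbon). For the measured compounds named here, no step between two measured compounds shows what this change does. The expected step from compound 1 to compound 3 is a number 63 percentage points lower from compound 1 to compound 3 (beyond the scatter), a drop beyond the scatter. For compound 3 the estimate in this assay is 45%, with a range from 10% to 95%.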

Compound 3, largest response reached (reported as percent of maximum), in percent of the reference or control that the assay uses: 84%
The estimate for compound 3 lay 39 percentage points below the measured number; the measured number falls inside the stated range.
By their numbers in this assay, from the lowest: compounds 2 and 3 (each within the scatter of the next); then compound 1.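

In this assay, putting isopropylamino in place of hydroxy on the carbonyl carbon brings a modest fall (a number 24 percentage points lower from compound 1 to compound 3 (beyond the scatter)). Compound 3 still gives 84% without any carboxy group, so on this chain a carboxy group is not needed for a clear response, although the response is smaller with 2-(isopropylcarbamoyl)ethyl in its place. Nothing available here explains this drop. Going by these compounds, whether methylamino, plain amino or methoxy on the same carbonyl carbon would keep more of the response remains open. So does the effect of a longer chain carrying the carboxylic acid.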